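Extending the hydroxyethyl arm of compound 3 through an amide

The source may report more compounds than this note shows. Statements on the series, on what has been measured and on what is new or still open speak of the compounds shown alone.

Measured so far:
compound 1 `CCCCCCCCN(C)C(=O)Cn1cc(Cc2cnc(OCC)nc2)c(=O)nc1SCc1ccc(F)cc1`: 7%
compound 2 `CCCCCCCCN(C)C(=O)Cn1cc(Cc2cnc(=O)n(CC)c2)c(=O)nc1SCc1ccc(F)cc1`: 5%
compound 3 `CCCCCCCCN(C)C(=O)Cn1cc(Cc2cnc(=O)n(CCO)c2)c(=O)nc1SCc1ccc(F)cc1`: 36%

In a functional assay on a cell-free system (plasma, Oryctolagus cuniculus) for inhibition of platelet-activating factor acetylhydrolase (Homo sapiens), tested at 100 nM (a lower number here means less inhibition, a higher number more inhibition at the concentration tested (going by the name of the read-out)), compound 3 gives the highest number of the three, with the steps of a number 29 percentage points higher from compound 1 to compound 3 (beyond the scatter) and a number 31 percentage points higher from compound 2 to compound 3 (beyond the scatter) both beyond the scatter; compounds 1 and 2 sit within the scatter of each other, as a number 2 percentage points lower from compound 1 to compound 2 (within the scatter) shows. Compound 4 `CCCCCCCCN(C)C(=O)Cn1cc(Cc2cnc(=O)n(CC(=O)NCCO)c2)c(=O)nc1SCc1ccc(F)cc1` carries the change ((2-hydroxyethyl)carbamoyl in place of hydroxymethyl on a saturated chain carbon bound to an aromatic nitrogen). Within the data shown here, the step that bears on it is a number 31 percentage points higher from compound 2 to compound 3 (beyond the scatter), where a hydroxy group was added on the same chain; in compound 4 that hydroxy-bearing chain is retained but pushed further out behind an amide, for which no measured step exists. The estimate for compound 4 therefore stays near compound 3, with a wide range, as a small step of a number 6 percentage points lower from compound 3 to compound 4 (within the scatter) is expected: compound 4 is estimated at 30%, between 10% and 55%.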

Compound 4, a percentage reported as inhibition, at one concentration (the size of the read-out at that concentration, not a potency): 40%
Compound 4: the middle estimate sits 10 percentage points below what was measured, within the range that was stated.
By their numbers in this assay, from the lowest: compounds 2 and 1 (each within the scatter of the next); then compounds 3 and 4 (each within the scatter of the next).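

In this assay the change to (2-hydroxyethyl)carbamoyl in place of hydroxymethyl gives a number 4 percentage points higher from compound 3 to compound 4 (within the scatter) and so shows that the arm on this saturated chain carbon bound to an aromatic nitrogen can be extended through an amide without losing what the hydroxy group brought. The gain over the ethyl chain stands at a number 35 percentage points higher from compound 2 to compound 4 (beyond the scatter) in this extended form. Nothing measured here explains this result. The compounds shown leave open whether the extended arm still needs its terminal hydroxy, and whether a carboxylic acid or an amine at that chain end would serve equally.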